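Compounds 1 to 3: no readable step so far

A few compounds are considered here, and "the series" means these few. Any claim that something is new, unique, unknown or untested is made for them only; others in the source may bear on it.

Compound 1 `CC(C)(C)[Si](C)(C)O[C@@H]1CCCO[C@@H]1/C=C\CO` gives > 100000 nM in a functional assay on A2780 cells (Homo sapiens) for antiproliferative activity, read by sulforhodamine B assay, with a stated time of 48 h; a higher number here means a weaker inhibitor of growth, a lower number a stronger inhibitor of growth
Compound 2 `CC(C)(C)[Si](C)(C)O[C@@H]1CCCO[C@@H]1/C=C/C(=O)O` gives > 100000 nM in this assay

Both values are limits of the assay and not numbers. Going by the values given here, the series so far shows the limit of > 100000 nM in this assay, at which 2 of the 2 values shown sit, and nothing else. Compound 2 therefore stands only at a limit, with no number to start from. Among the compounds with values here, the one measured step is a step that the two limits leave unreadable from compound 1 to compound 2 and offers no size to carry forward.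

Compound 3 `C=C[C@H]1OCCC[C@H]1O[Si](C)(C)C(C)(C)C` keeps the shared core, and the change is vinyl in place of 2-carboxyethenyl on a saturated ring carbon in the same place.

Within the data shown here, no step of definite size can be derived for this assay, and no gain in growth inhibition is expected. The expected step is a number no higher from compound 2 to compound 3 (the limit leaves the size open) as an estimate only. This expectation rests on compound 2, whose limit is > 100000 nM in this assay. Compound 3 is estimated at 100000 nM with an expected range from 40000 nM to 200000 nM in this assay, and a further limit is the likeliest report.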

Compound 3, concentration for 50% growth inhibition: 86000 nM
Estimate against measurement, compound 3: 1.2-fold (0.07 log units) above; low and high end bracket the measured number.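

In this assay, going by these compounds alone, compound 3, with vinyl on a saturated ring carbon next to the ring oxygen, gives 86000 nM, the first number rather than a limit. Vinyl in place of 2-carboxyethenyl gives an at least 1.1-fold lower number from compound 2 to compound 3 (0.06 log units; that floor lies within the scatter), and vinyl in place of 3-hydroxyprop-1-en-1-yl gives an at least 1.1-fold lower number from compound 1 to compound 3 (0.06 log units; that floor lies within the scatter). Both steps are floors set against a limit, and neither shows a firm size or a real gain in growth inhibition at this position: the limit of > 100000 nM in this assay, at which 2 of the 3 values shown sit.

From the compounds shown here alone, what an amine or a longer alkyl chain would give in this place remains open. Also open, going by these compounds, is what a free hydroxyl would give in place of the group of 8 heavy atoms, which all three compounds keep.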